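The source may hold more compounds than are shown below. What is called first, only, known or untested is meant among the compounds shown, and "the series" means these compounds.

In a functional assay on the whole organism (strain Sprague-Dawley) for inhibition, with Rattus norvegicus as the target, with a stated time of 10 min (on this read-out lower numbers stand for an effect already at smaller amounts and higher numbers for an effect only at larger amounts of compound), compound 1 `COc1cccc(-c2ncc(C(=O)O)c(=O)[nH]2)c1` gives 10 mg/kg, compound 2 `COc1ccc(OC)c(-c2ncc(C(=O)O)c(=O)[nH]2)c1` gives 1 mg/kg and compound 3 `CCOc1ccc(OC)cc1-c1ncc(C(=O)O)c(=O)[nH]1` gives 0.2 mg/kg, the lowest of the three numbers. Compound 4 `CCCOc1ccc(OC)cc1-c1ncc(C(=O)O)c(=O)[nH]1` turns the ethoxy of compound 3 into propoxy, with methyl in place of hydrogen on a saturated chain carbon, two bonds along the chain from an oxygen on an aromatic ring. Among the measured compounds shown here, the closest precedent is methoxy to ethoxy, a 5.0-fold lower number from compound 2 to compound 3 (0.70 log units; beyond the scatter), a modest step beyond the scatter. The steps of a 10-fold lower number from compound 1 to compound 2 (1.00 log units; beyond the scatter) and a 50-fold lower number from compound 1 to compound 3 (1.70 log units; beyond the scatter) replace hydrogen on an aromatic carbon and bear less directly. One chain extension cannot show whether the trend continues, so only a small further drop in this assay is expected, possibly none beyond the scatter. The estimated step is a 1.3-fold lower number from compound 3 to compound 4 (0.12 log units; within the scatter). Compound 4 is expected at 0.15 mg/kg, within an estimated range of 0.04 mg/kg to 0.6 mg/kg.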

Compound 4, dose for 50% inhibition: 0.3 mg/kg
Compound 4: the middle estimate sits 2.0-fold (0.30 log units) below what was measured; the range from low to high includes it.
By their numbers in this assay, from the lowest: compounds 3 and 4 (each within the scatter of the next); then compound 2; then compound 1.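

In this assay the change from ethoxy to propoxy (a 1.5-fold higher number from compound 3 to compound 4 (0.18 log units; within the scatter)) stays within the scatter, so the drop seen from methoxy to ethoxy does not visibly continue at this position. The propoxy group still keeps the gain over methoxy (a 3.3-fold lower number from compound 2 to compound 4 (0.52 log units; beyond the scatter)) and over hydrogen (a 33-fold lower number from compound 1 to compound 4 (1.52 log units; beyond the scatter)), so this position tolerates the added methyl without a loss beyond the scatter. Nothing available here accounts for this result. On these data alone, whether a longer chain such as butoxy, a branched isopropoxy or an amine at the chain end would hold this level remains open.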